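The source may hold more compounds than are shown below. What is called first, only, known or untested is meant among the compounds shown, and "the series" means these compounds.

Measured compounds in a functional assay on aorta (Rattus norvegicus); a lower number here means a stronger inhibitor, a higher number a weaker inhibitor:

Compound 1 `O=c1ccc(CO)nn1Cc1ccccc1` gives > 100000 nM, which is a limit of this assay rather than a number.
Compound 2 `O=c1ccc(CCO)nn1Cc1ccccc1` gives > 100000 nM, again a limit and not a number.
Compound 3 `Cn1nc(CCCO)ccc1=O` gives > 100000 nM, also a limit and not a number.

Compound 3 thus stands at the edge of what this assay can report: its value is a limit, and the two further values shown are limits of the same kind (the limit of > 100000 nM in this assay, at which 3 of the 3 values shown sit). Among the measured compounds shown here, no compound in this set has a readable number. The step from compound 1 to compound 2 a step that the two limits leave unreadable from compound 1 to compound 2 cannot be read either, since both ends sit at the limit.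

Compound 4 `O=c1ccc(CCCO)nn1Cc1ccccc1` differs from compound 3 by one change: phenyl in place of hydrogen on a saturated chain carbon bound to an aromatic nitrogen. For the measured compounds named here, no measured step bears on this change, so there is nothing to scale an expectation by; the only guide is that every value shown sits at the limit (the limit of > 100000 nM in this assay, at which 3 of the 3 values shown sit). The step from compound 3 to compound 4 is therefore expected to be a number no higher from compound 3 to compound 4 (the limit leaves the size open), with a high chance that only a limit is reported again. For compound 4 in this assay the estimated value is 100000 nM, with a range from 20000 nM to 500000 nM.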

Compound 4, half-maximal inhibitory concentration: > 100000 nM
Compound 4: no number, only a limit; the forecaster's own chance of this, stated with the estimate: 85%; the middle value sits exactly at the limit.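

In this assay compound 4 gives > 100000 nM, a limit and not a number, so the steps to it from compound 1, compound 2 and compound 3 cannot be read: the limit of > 100000 nM in this assay, at which 4 of the 4 values shown sit. The compounds shown leave open which structural change, if any, would give a readable number in this assay.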